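A few compounds are considered here, and "the series" means these few. Any claim that something is new, unique, unknown or untested is made for them only; others in the source may bear on it.

Measured so far in an ADME assay on cells (Hepatocyte, Rattus norvegicus) for metabolic stability; a lower number here means slower removal, a higher number faster removal of the compound:
compound 1 `CN(C)C(=O)CN1CCC(c2cc3c(-c4ccc(=O)n(C5CCOCC5)c4)ccnc3[nH]2)CC1`: 2.3 uL/min
compound 2 `COc1cc(=O)n(C)cc1-c1ccnc2[nH]c(C3CCN(CC(=O)N(C)C)CC3)cc12`: < 1 uL/min, which is a limit of this assay and not a number.
Not yet measured: compound 3 `CN(C)C(=O)CN1CCC(c2cc3c(-c4ccc(=O)n(CC5CCOCC5)c4)ccnc3[nH]2)CC1`.

For the measured compounds named here, compound 1 stands at the only value given as a number in this assay, 2.3 uL/min. Going by the values given here, compound 2 reaches only a limit there, (the limit of < 1 uL/min in this assay, at which 1 of the 2 values shown sits), so no step between compound 2 and compound 1 can be sized and compound 2 is set aside for the present step. Compound 3 differs from compound 1 in one place: (oxan-4-yl)methyl in place of oxan-4-yl on an aromatic nitrogen. No measured pair in the series shows how this change moves clearance, so nothing shown fixes the size or direction of the step. With (oxan-4-yl)methyl entering where oxan-4-yl leaves, the step is expected to be small: estimated a 1.4-fold higher number from compound 1 to compound 3 (0.14 log units; within the scatter), leaning toward faster removal if anything, and quite possibly none beyond the usual scatter. For compound 3 the expected value in this assay is 3.2 uL/min, with a range from 1.2 uL/min to 9 uL/min.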

Compound 3, intrinsic clearance in a liver preparation (reported as CLH), per the amount of preparation that the assay uses: 1.8 uL/min
For compound 3 the middle estimate is 1.8-fold (0.25 log units) above the measured one; the range from low to high includes it.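

In this assay, for the compounds shown here, (oxan-4-yl)methyl in place of oxan-4-yl on the aromatic nitrogen gives a 1.3-fold lower number from compound 1 to compound 3 (0.11 log units; within the scatter), the first step that can be read at this position. The position therefore takes the larger group, with its 7 heavy atoms against 6, with no change beyond the scatter, and compound 1 and compound 3 cannot be ranked on this read-out. Compound 2 gives a limit and not a number, so no step involving it can be read: the limit of < 1 uL/min in this assay, at which 1 of the 3 values shown sits.

Only one change on the aromatic nitrogen is shown, so it remains open whether a longer chain ending in an amine or a carboxylic acid would move the number in this assay beyond the scatter. A group without the ring oxygen, such as cyclohexyl, or an open-chain ether, such as 2-methoxyethyl, is also unplaced at this position, and this single pair sets no trend for either.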